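This account rests on a few compounds, and the source may have more. Where it says the series, first, only, none or still open, it means among the compounds named here.

In a functional assay on MCF7 cells (Homo sapiens) for cytotoxicity, read by sulforhodamine B assay (on this read-out higher numbers stand for lower toxicity in this test and lower numbers for higher toxicity in this test), three compounds built on one shared core have been tested. Compound 1 `COc1ccc(/C=N\NC(=S)NC(C)(C)CCC[C@](C)(O)[C@@H]2CC=C(C)CC2)cc1` gives only a limit of the assay, > 100000 nM. Compound 2 `CC1=CC[C@@H]([C@@](C)(O)CCCC(C)(C)NC(=S)N/N=C\c2ccc(O)cc2)CC1` gives 56400 nM. Compound 3 `CC1=CC[C@@H]([C@@](C)(O)CCCC(C)(C)NC(=S)N/N=C\c2cccc([N+](=O)[O-])c2)CC1` gives 47300 nM. Of the two numbers that are not limits, compound 2 holds the larger one, yet a 1.2-fold lower number from compound 2 to compound 3 (0.08 log units; within the scatter) shows that gap to sit within the scatter. The steps of an at least 1.7-fold lower number from compound 1 to compound 2 (0.24 log units; that floor lies within the scatter) and an at least 2.1-fold lower number from compound 1 to compound 3 (0.32 log units; beyond the scatter) start from a limit (the limit of > 100000 nM in this assay, at which 1 of the 3 values shown sits), so only their floors are known. Compound 4 `CC1=CC[C@@H]([C@@](C)(O)CCCC(C)(C)NC(=S)N/N=C(/C)c2ccccc2)CC1` differs from compound 2 in one place: a group of 9 heavy atoms (8 carbon, 1 nitrogen; one six-membered aromatic ring of carbon only) in place of a group of 9 heavy atoms (7 carbon, 1 nitrogen, 1 oxygen; one six-membered aromatic ring of carbon only), on an amide-type nitrogen. The measured steps that exchanged the group on the carbon with a double bond to nitrogen, a 1.2-fold lower number from compound 2 to compound 3 (0.08 log units; within the scatter) and an at least 2.1-fold lower number from compound 1 to compound 3 (0.32 log units; beyond the scatter), moved the number little or only to a floor set by a limit, so for a 1.1-fold higher number from compound 2 to compound 4 (0.03 log units; within the scatter) no step beyond the scatter in either direction is expected. Compound 4 is therefore estimated at 60000 nM, with a range from 25000 nM to 150000 nM.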

Compound 4, concentration lethal to 50% of the cells: > 100000 nM
Compound 4: only a limit was reported (the forecaster's own chance of this, stated with the estimate: 30%); at least 1.6-fold (0.22 log units) between middle value and limit.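

At the amide-type nitrogen whose other neighbour is the thiocarbonyl carbon, the exchange gives in this assay an at least 1.7-fold higher number from compound 2 to compound 4 (0.24 log units; that floor lies within the scatter), so this floor alone does not set the two apart. Compound 4 gives only a limit, > 100000 nM, and is the second compound to do so, whereas the exchanges measured earlier at this place led to compound 2 and compound 3, which both carry numbers: the limit of > 100000 nM in this assay, at which 2 of the 4 values shown sit. The step from compound 1 to compound 4 cannot be read.

The compounds shown leave open where the true value of compound 4 lies and, with it, how large the step at this place really is. They also leave open whether an amine or a carboxylic acid on the aromatic ring would give a number or another limit.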